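The source may hold more compounds than are shown below. What is called first, only, known or untested is meant among the compounds shown, and "the series" means these compounds.

Working notes on the series.

Compound 1 `COCCOC(=O)c1cc(N)c(Nc2ccc(C#N)cc2)cc1Oc1c(C)cc(/C=C/C#N)cc1C` carries a 2-methoxyethoxy group on the carbonyl carbon of the shared core. In a physicochemical assay for lipophilicity, read by HPLC, measured as octanol-water partition, with a stated time of 24 h, at pH 7.4 (a higher number here means a more lipophilic compound, a lower number a more polar compound), compound 1 gives > 5, which is a limit of the assay and not a number, so where compound 1 stands is known only as that limit (the limit of > 5 in this assay, at which 1 of the 3 values shown sits). Compound 2 `Cc1cc(/C=C/C#N)cc(C)c1Oc1cc(Nc2ccc(C#N)cc2)c(N)cc1C(=O)NN` gives 2.31 in this assay, and compound 3 `Cc1cc(/C=C/C#N)cc(C)c1Oc1cc(Nc2ccc(C#N)cc2)c(N)cc1C(=O)NCCCO` gives 3.22. The measured steps are all large: a number at least 2.69 log units lower from compound 1 to compound 2 (beyond the scatter) and a number at least 1.78 log units lower from compound 1 to compound 3 (beyond the scatter), with a number 0.91 log units higher from compound 2 to compound 3 (beyond the scatter) between the two amide-type compounds.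

Compound 4 `COC(=O)c1cc(N)c(Nc2ccc(C#N)cc2)cc1Oc1c(C)cc(/C=C/C#N)cc1C` differs from compound 1 by one change: hydrogen in place of methoxymethyl on a saturated chain carbon bound to an oxygen next to a carbonyl group. For the measured compounds named here, none of the measured steps touches this part of the molecule; the two steps from compound 1 replaced the whole 2-methoxyethoxy group with amide-type nitrogen groups bearing donors, so they only set the scale of what a change at this position can do. The removal of a methoxymethyl group is expected to give a step of a number no higher from compound 1 to compound 4 (the limit leaves the size open), close to or within the scatter. Compound 4 is therefore estimated at 5, with a range from 4.4 to 5.6, and a fair chance that the assay again reports only a limit.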

Compound 4, partition coefficient: 4.15
The estimate for compound 4 lay 0.85 log units above the measured number, outside the stated range (below it).
By their numbers in this assay, from the lowest: compound 2; then compound 3; then compound 4. At a limit, above all of these: compound 1.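

For the compounds shown here, compound 4 gives the first measured number for a change that keeps the oxygen on the carbonyl carbon: with hydrogen in place of methoxymethyl on this saturated chain carbon, the result is a number at least 0.85 log units lower from compound 1 to compound 4 (beyond the scatter) in this assay. The value of compound 1 is a limit of the assay and not a number, so this step has a bound only: the limit of > 5 in this assay, at which 1 of the 4 values shown sits.
Against the two amide-type compounds, the methoxy compound gives a number 0.93 log units higher from compound 3 to compound 4 (beyond the scatter) and a number 1.84 log units higher from compound 2 to compound 4 (beyond the scatter).

The compounds shown leave open how the number moves along a simple carbon chain on this oxygen, such as ethoxy or butoxy, set against the 2-methoxyethoxy group. Also open, going by these compounds, is where a carboxylic acid on the carbonyl carbon, or a chain ending in a dimethylamino group, would stand in this assay.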